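A few compounds are considered here, and "the series" means these few. Any claim that something is new, unique, unknown or untested is made for them only; others in the source may bear on it.

Working notes on the chalcone-type series with a shared pyrazole core.

Compound 1 `COc1ccc(-c2cc(/C=C/C(=O)c3ccc(N)cc3)[nH]n2)cc1` was tested in a functional assay on NCI-H322M cells (Homo sapiens) for cytotoxicity, read by sulforhodamine B assay, with a stated time of 48 h, tested at 1 uM (on this read-out lower numbers stand for a stronger effect and higher numbers for a weaker effect at the one concentration tested), and gives 69%. Compound 2 `COc1cc(-c2cc(/C=C/C(=O)c3ccc(F)c(F)c3)[nH]n2)cc(OC)c1OC` in this assay gives 86%. Among the compounds with values here, of the two numbers measured so far, compound 1 stands lowest, and the gap from compound 1 to compound 2 lies beyond the usual scatter, so on this read-out compound 1 shows the stronger effect. Within the data shown here, no pair of measured compounds differs in only one place, so no single-change step has been observed.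

Compound 3 `COc1ccc(-c2cc(/C=C/C(=O)c3ccc(N)cc3)[nH]n2)cc1OC` has not yet been measured in this assay. It differs from compound 1 by methoxy in place of hydrogen on an aromatic carbon. Among the measured compounds shown here, no measured pair shows what a second methoxy group does on this ring, so the expectation rests on compound 1 alone: the step from compound 1 to compound 3 is expected to be a number 1 percentage points higher from compound 1 to compound 3 (within the scatter), that is, not beyond the scatter in either direction. Compound 3 is accordingly expected to give about 70% in this assay, estimated to fall between 55% and 85%.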

Compound 3, a percentage reported as activity, at one concentration (the size of the read-out at that concentration, not a potency): 95%
The estimate for compound 3 lay 25 percentage points below the measured number; the measured number lies above the stated range.
By their numbers in this assay, from the lowest: compound 1; then compounds 2 and 3 (each within the scatter of the next).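

In this assay, within the data shown here, methoxy in place of hydrogen on an aromatic carbon, ortho to a methoxy group and meta to a large group, gives the first single-change step: a number 26 percentage points higher from compound 1 to compound 3 (beyond the scatter). This shows that the carbon carrying only hydrogen in compound 1 is not indifferent to substitution, since the added methoxy weakens the effect at the one concentration tested, although this rests on a single pair and says nothing about potency. Nothing available on these compounds accounts for the size or direction of this step.

The compounds shown leave open whether the loss belongs to methoxy as such or to any group on this carbon, a question that a fluorine, a hydroxyl or a methyl group there would address. Also open, as far as these compounds go, is whether the step depends on the methoxy group already present on the ring, which an ethoxy group in the new place, or the new methoxy alone on that ring, would help to separate.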